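The compounds below may be only part of what the source reports. "The series", "measured", "known", "first", "only" and "open" are said of these compounds alone.

Compound 1 `CC1CCN(c2c(S(=O)(=O)c3cccc(Cl)c3)cnc3ccc(Cl)cc23)CC1` is the starting point here. In an assay on isolated protein for displacement of a labelled ligand from metabotropic glutamate receptor 5 (Homo sapiens), with a stated time of 60 min, tested at 1 uM (on this read-out lower numbers stand for less inhibition and higher numbers for more inhibition at the one concentration tested (going by the name of the read-out)), compound 1 gives 92%, the highest of the three numbers in hand. Compound 2 `CC1CCN(c2c(S(=O)(=O)c3ccc(F)cc3)cnc3ccc(Cl)cc23)CC1` gives 89%, and the step of a number 3 percentage points lower from compound 1 to compound 2 (within the scatter) stays within the scatter. Compound 3 `CC1CCN(c2c(S(=O)(=O)c3ccccc3)cnc3ccc(Cl)cc23)CC1` gives 59%, so the step of a number 33 percentage points lower from compound 1 to compound 3 (beyond the scatter) is large, and the step of a number 30 percentage points lower from compound 2 to compound 3 (beyond the scatter) also goes beyond the scatter. Compound 4 `COc1ccc2ncc(S(=O)(=O)c3cccc(Cl)c3)c(N3CCC(C)CC3)c2c1` differs from compound 1 in a single place: methoxy in place of chloro on an aromatic carbon. Among the measured compounds shown here, both measured steps altered the group on the sulfonyl sulfur, not this aromatic carbon of the shared core, so no measured step bears directly on the change. A modest loss is expected, a number 12 percentage points lower from compound 1 to compound 4 (beyond the scatter). Compound 4 is estimated at 80%, within 55% to 95%.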

Compound 4, a percentage reported as inhibition, at one concentration (the size of the read-out at that concentration, not a potency): -3%
Compound 4: the middle estimate sits 83 percentage points above what was measured; measured number outside the range, below it.
By their numbers in this assay, from the lowest: compound 4; then compound 3; then compounds 2 and 1 (each within the scatter of the next).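

Methoxy in place of chloro on this aromatic carbon of the shared core gives a number 95 percentage points lower from compound 1 to compound 4 (beyond the scatter) in this assay, so inhibition at the one concentration tested is lost altogether. This position therefore matters as much as the group on the sulfonyl sulfur, and chloro cannot be swapped freely here. Nothing at hand explains why this change has such an effect.

As far as these compounds go, it remains open whether methyl, a nitrile or an amine on this carbon would keep the inhibition. From the compounds shown here alone, it is also open whether methoxy would do the same with the sulfonyl groups of compound 2 or compound 3.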